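Swapping the chlorophenyl arm for naphthyl: cytotoxicity outlook

The source may hold more compounds than are shown below. What is called first, only, known or untested is meant among the compounds shown, and "the series" means these compounds.

The series shares one core, and its members differ only in the aryl group attached to it. Compound 1 `Cc1cc(C#N)cc(C)c1Oc1nc(Nc2ccc(C#N)cc2)ncc1-c1ccc(Cl)cc1` carries a 4-chlorophenyl group there; in an ADME assay on MT4 cells (Homo sapiens) for cytotoxicity, read by MTT assay, with a stated time of 5 days (a higher number here means that more compound is tolerated, a lower number that less compound is tolerated), compound 1 gives 72600 nM. Compound 2 `Cc1cc(C#N)cc(C)c1Oc1nc(Nc2ccc(C#N)cc2)ncc1-c1ccc(N)cc1` carries a 4-aminophenyl group instead, and in this assay compound 2 gives 310 nM. Compound 3 `Cc1cc(C#N)cc(C)c1Oc1nc(Nc2ccc(C#N)cc2)ncc1-c1cncnc1` carries a pyrimidin-5-yl group; its result in this assay, > 298000 nM, is a limit of the assay rather than a number, which is the case described by the limit of > 298000 nM in this assay, at which 1 of the 3 values shown sits. Among the two numbers shown, compound 1 stands highest, with compound 2 nearest to it at a 230-fold lower number from compound 1 to compound 2 (2.37 log units; beyond the scatter).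

Compound 4 `Cc1cc(C#N)cc(C)c1Oc1nc(Nc2ccc(C#N)cc2)ncc1-c1ccc2ccccc2c1` has not yet been measured in this assay. It differs from compound 1 as follows: naphthalen-2-yl in place of 4-chlorophenyl on an aromatic carbon.

Two measured steps leave the same position of compound 1. The step of a 230-fold lower number from compound 1 to compound 2 (2.37 log units; beyond the scatter) is large, and the step of an at least 4.1-fold higher number from compound 1 to compound 3 (0.61 log units; beyond the scatter) is at least modest in the opposite direction. Neither replaces the 4-chlorophenyl group with a second ring of carbon only, so they give no direct guide to compound 4. The estimated step is therefore a 1.5-fold lower number from compound 1 to compound 4 (0.16 log units; within the scatter), a change that is expected to stay near the scatter. Compound 4 is expected to give about 50000 nM in this assay, within a range from 15000 nM to 160000 nM.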

Compound 4, half-maximal cytotoxic concentration: 8460 nM
Estimate against measurement, compound 4: 5.9-fold (0.77 log units) above, outside the stated range (below it).
By their numbers in this assay, from the lowest: compound 2; then compound 4; then compound 1. At a limit, above all of these: compound 3.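

In this assay, exchanging one all-carbon aryl group for another at this position is not a neutral change: although neither the 4-chlorophenyl group nor naphthalen-2-yl has hydrogen-bond donors or acceptors, the exchange moves the number beyond the scatter (an 8.6-fold lower number from compound 1 to compound 4 (0.93 log units; beyond the scatter)). Compound 4 also lies well clear of the two other compounds, with large steps on both sides (a 27-fold higher number from compound 2 to compound 4 (1.44 log units; beyond the scatter); an at least 35-fold lower number from compound 3 to compound 4 (1.54 log units; beyond the scatter)), so the aryl groups shown here spread over a wide range rather than falling into two extremes. Compound 3 stands at a limit of the assay, and the step from it is a bound only: the limit of > 298000 nM in this assay, at which 1 of the 4 values shown sits.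

The compounds shown do not separate the loss of the chlorine from the gain of the second ring, and an unsubstituted phenyl group would stand between those two changes. They also leave open how a 4-hydroxyphenyl or a 4-methoxyphenyl group would compare with the 4-aminophenyl group of compound 2.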